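A few compounds are considered here, and "the series" means these few. Any claim that something is new, unique, unknown or untested is made for them only; others in the source may bear on it.

Measured compounds in an ADME assay on THP-1 cells (Homo sapiens) for cytotoxicity, read by WST assay, with a stated time of 24 h; a lower number here means a stronger inhibitor, a higher number a weaker inhibitor:
compound 1, `O=C(Nc1ccccc1F)c1ccc2cccc(O)c2n1`, gives > 30000 nM, a limit of the assay.
compound 2, `O=C(Nc1ccc(Cl)cc1)c1ccc2cccc(O)c2n1`, gives > 30000 nM, also a limit of the assay.

Compound 2 therefore stands only at a limit in this assay, with no number of its own. Compound 3 is `O=C(Nc1ccccc1Br)c1ccc2cccc(O)c2n1`. The change from compound 2 to compound 3 is 2-bromophenyl in place of 4-chlorophenyl on an amide-type nitrogen. Among the measured compounds shown here, the only measured step at this place, a step that the two limits leave unreadable from compound 1 to compound 2, is unreadable because of the limit of > 30000 nM in this assay, at which 2 of the 2 values shown sit. No readable step exists, so for compound 3 no movement beyond the scatter is expected and a further limit is the likely outcome. Compound 3 is estimated at 40000 nM (range 20000 nM to 100000 nM). The expected step that the limit leaves unreadable from compound 2 to compound 3 is thus held within the scatter.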

Compound 3, half-maximal inhibitory concentration: > 30000 nM
Compound 3: only a limit was reported (the forecaster's own chance of this, stated with the estimate: 80%); the middle value lies beyond the limit too.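

Compound 1, compound 2 and compound 3 all stand only at a limit, so no step among them can be read: the limit of > 30000 nM in this assay, at which 3 of the 3 values shown sit.

The compounds shown leave open whether 2-fluorophenyl, 4-chlorophenyl and 2-bromophenyl differ at all in this assay.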